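Cyclopropyl for methyl on the amide nitrogen, second core

The compounds below may be only part of what the source reports. "The series", "measured", "known", "first", "only" and "open" are said of these compounds alone.

Three compounds of the series have numbers in a physicochemical assay for lipophilicity, at pH 7.4; on this read-out higher numbers stand for higher lipophilicity and lower numbers for lower lipophilicity. Compound 1 `CNC(=O)c1cc(C(=O)NC2CC2)cc2c1OC[C@@]2(C)c1ccccc1` gives 4. Compound 2 `CNC(=O)c1cc(C(=O)NC)c2c(c1)[C@](C)(c1ccccc1)CO2` gives 3.4, and compound 3 `CNC(=O)c1cc(C(=O)NC)c2c(c1)[C@H](c1ccccc1)[C@@H](CF)O2` gives 3.3. Compound 3 has the lowest of the three numbers; its gap to compound 2 lies within the scatter, whereas compound 1 stands beyond the scatter above it.

Compound 1 differs from compound 2 in one place: cyclopropyl in place of methyl on an amide-type nitrogen. This change made a step of a number 0.60 log units higher from compound 2 to compound 1 (beyond the scatter), a modest rise.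

Compound 3 and compound 2 differ in their cores; the difference between the two cores is not broken down here.

Compound 4 `CNC(=O)c1cc(C(=O)NC2CC2)cc2c1O[C@H](CF)[C@H]2c1ccccc1` has not yet been measured in this assay. It differs from compound 3 in one place: cyclopropyl in place of methyl on an amide-type nitrogen. The place reads word for word the same as for the earlier pair, an amide-type nitrogen whose other neighbour is a carbonyl carbon, so this is the same change, now made on the core of compound 3 rather than on the core of compound 2.

A step of a number 0.60 log units higher from compound 3 to compound 4 (beyond the scatter) is expected from this change, resting on the single measured occurrence, a number 0.60 log units higher from compound 2 to compound 1 (beyond the scatter), and on the two cores otherwise giving numbers within the scatter of each other for compound 2 and compound 3. Compound 4 is therefore estimated at 3.9, with a likely range from 3.5 to 4.3.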

Compound 4, distribution coefficient: 3.9
Compound 4: the middle estimate sits on the measured number at the digits printed; the measured number falls inside the stated range.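

In this assay, cyclopropyl in place of methyl on an amide-type nitrogen gives a number 0.60 log units higher from compound 3 to compound 4 (beyond the scatter), and the same change on the other core gives a number 0.60 log units higher from compound 2 to compound 1 (beyond the scatter), so in these two pairs the step carries from the core of compound 2 to the core of compound 3 at the same printed size. This is agreement between two pairs in a single read-out, which is enough to support carrying the change between these two cores but does not establish a rule for other cores in the series or for other groups on that nitrogen. The data shown offer nothing that accounts for the step or for its repeating on the second core.

On these data alone, it remains open whether a larger ring such as cyclobutyl, a longer chain such as n-propyl, or a chain ending in an amine or a carboxylic acid on the same nitrogen would also give a step of predictable size on both cores. Also open, as far as these compounds go, is whether the methyl on the other amide-type nitrogen, which compound 1 and compound 4 both retain, would respond in the same way to cyclopropyl.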